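A Biaryl Replacement on a Shared Acrylamide Core

A few compounds are considered here, and "the series" means these few. Any claim that something is new, unique, unknown or untested is made for them only; others in the source may bear on it.

Compound 1 `C=CC(=O)Nc1cccc(Nc2ncnc(Nc3ccc(Oc4ccc(OC)cc4)cc3)n2)c1` returns only a limit in a functional assay on Ramos cells (Homo sapiens) for antiproliferative activity, read by CCK-8 assay, with a stated time of 24 h (on this read-out higher numbers stand for weaker inhibition and lower numbers for stronger inhibition), where compound 1 gives > 100000 nM. Compound 2 `C=CC(=O)Nc1cccc(Nc2ncnc(Nc3ccc(C(=O)Nc4ccc(C)cn4)cc3)n2)c1` likewise reaches only a limit, and in this assay compound 2 gives > 100000 nM. The step that the two limits leave unreadable from compound 1 to compound 2 therefore cannot be read, as both values sit at the limit of > 100000 nM in this assay, at which 2 of the 2 values shown sit. Compound 3 `C=CC(=O)Nc1cccc(Nc2ncnc(Nc3ccc(-c4ccc(Cl)nc4)cc3)n2)c1` carries the change (6-chloropyridin-3-yl in place of (5-methylpyridin-2-yl)carbamoyl on an aromatic carbon). No readable measured step bears on this change, and compound 2 stands at the limit of this assay. Compound 3 is expected to stay close to that limit, with a step of an at least 1.2-fold lower number from compound 2 to compound 3 (0.09 log units; that floor lies within the scatter) and an estimated value of 80000 nM in this assay, within 10000 nM to 300000 nM.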

Compound 3, half-maximal inhibitory concentration: 160000 nM
The estimate for compound 3 lay 2.0-fold (0.30 log units) below the measured number; measured number inside the range.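

The steps from compound 1 and compound 2 to compound 3 cannot be read, because compound 1 and compound 2 return only limits: the limit of > 100000 nM in this assay, at which 2 of the 3 values shown sit. The compounds shown leave open which group on the shared core, if any, gives a readable difference in this assay from the others.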